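Ethyl to 4-chlorophenyl on the ring nitrogen

A few compounds are considered here, and "the series" means these few. Any claim that something is new, unique, unknown or untested is made for them only; others in the source may bear on it.

Compound 3 `CCOC(=O)c1cc(-c2cccc(OC(=O)NC3CCCCC3)c2)nn1CC` gives 507 nM in an assay on isolated protein for inhibition of Fatty-acid amide hydrolase 1 (Homo sapiens), read by fluorescence, with a stated time of 30 min (a higher number here means a weaker inhibitor, a lower number a stronger inhibitor), the highest of the three numbers in hand. Compound 1 `CCOC(=O)c1cc(-c2cccc(OC(=O)NC3CCCCC3)c2)n(C)n1` gives 303 nM in this assay, within the scatter of compound 3. Compound 2 `NC(=O)c1cc(-c2cccc(OC(=O)NC3CCCCC3)c2)n(-c2ccc(Cl)cc2)n1` gives 174 nM, a gap beyond the scatter from compound 3. Compound 4 `CCOC(=O)c1cc(-c2cccc(OC(=O)NC3CCCCC3)c2)nn1-c1ccc(Cl)cc1` differs from compound 3 by 4-chlorophenyl in place of ethyl on an aromatic nitrogen. Going by the values given here, no step between measured compounds covers this change on its own. Among the compounds with values here, the expectation of a lower number rests on compound 2 at 174 nM, the only compound carrying 4-chlorophenyl on the ring nitrogen, though it also differs from compound 4 elsewhere on the core, so the read-across is indirect. A modest step downward is expected: a 2.3-fold lower number from compound 3 to compound 4 (0.36 log units; beyond the scatter). Compound 4 is estimated at 220 nM, within 70 nM to 650 nM.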

Compound 4, half-maximal inhibitory concentration: 353 nM
The estimate for compound 4 lay 1.6-fold (0.21 log units) below the measured number, within the range that was stated.
By their numbers in this assay, from the lowest: compounds 2, 1, 4 and 3 (each within the scatter of the next, the first and the last beyond it).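

With the ethoxycarbonyl group kept in place, 4-chlorophenyl in place of ethyl on the aromatic nitrogen gives a 1.4-fold lower number from compound 3 to compound 4 (0.16 log units; within the scatter) in this assay. Going by these compounds alone, this is the first matched reading at this position, and it shows that the larger group, with its six-membered aromatic ring, leaves the number within the scatter. No accompanying measurement accounts for this result.

Open, from the compounds shown here alone, is whether unsubstituted phenyl or benzyl on this nitrogen would read the same, which would separate the ring from the chlorine. Also open, going by these compounds, is whether 4-chlorophenyl would behave alike with a carboxylic acid in place of the ethoxycarbonyl group.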